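Adding an acetyl to compound 3

This account rests on a few compounds, and the source may have more. Where it says the series, first, only, none or still open, it means among the compounds named here.

Measured so far in a functional assay for inhibition, with Homo sapiens as the target; a higher number here means that more compound is needed for the effect, a lower number that less compound is needed:
- compound 1 `Nc1ccc(C2=NNC(=O)CC2)cc1` gives 46.4 ug/mL
- compound 2 `CC(=O)Nc1ccc(C2=NNC(=O)CC2)cc1` gives 1 ug/mL
- compound 3 `CN1N=C(c2ccc(N)cc2)CCC1=O` gives > 46.4 ug/mL

Compound 3 has no number in this assay and stands at the limit of > 46.4 ug/mL in this assay, at which 1 of the 3 values shown sits, which is a limit.

Compound 4 `CC(=O)Nc1ccc(C2=NN(C)C(=O)CC2)cc1` differs from compound 3 by one change, (acetyl in place of hydrogen on a nitrogen on an aromatic ring). This is the acetyl in place of hydrogen on a nitrogen on an aromatic ring, amino to acetamido.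

Within the data shown here, two measured steps bear on it. The same change appears in a 46-fold lower number from compound 1 to compound 2 (1.67 log units; beyond the scatter), a large step beyond the scatter. The other is a number no lower from compound 1 to compound 3 (the limit leaves the size open), for the methyl in place of hydrogen on an amide-type nitrogen in a ring, and the limit leaves its size open. Compound 4 keeps that methyl, so the acetyl step must carry over to a different background, and it has been seen only once.

A large move to a lower number is therefore expected, resting on compound 2 and its a 46-fold lower number from compound 1 to compound 2 (1.67 log units; beyond the scatter), with a second limit still possible. The expected step is an at least 4.6-fold lower number from compound 3 to compound 4 (0.66 log units; beyond the scatter). Compound 4 is estimated at 10 ug/mL, with an expected range of 1 ug/mL to 100 ug/mL.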

Compound 4, half-maximal effective concentration: > 46.4 ug/mL
Compound 4 was reported as a limit; the forecaster's own chance of this, stated with the estimate: 35%; middle value at least 4.6-fold (0.66 log units) from the limit.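

In this assay the methyl in place of hydrogen on an amide-type nitrogen in a ring gives an at least 46-fold higher number from compound 2 to compound 4 (1.66 log units; beyond the scatter) and so takes on a readable size, which the limit on the earlier pair had left open. The low number of compound 2 therefore depends on the amide hydrogen as well as on the acetamido group, and the methyl change can now be set side by side on two cores: the same change on two cores in this assay, a number no lower (the limit leaves the size open) from compound 1 to compound 3 and an at least 46-fold higher number (1.66 log units; beyond the scatter) from compound 2 to compound 4; the limit leaves it open whether they differ. The acetyl step on the methylated core cannot be read, with limits at both of its ends, so the large gain seen on the core of compound 1 is not shown to carry over, and the methylated compounds now rest at one ceiling: the limit of > 46.4 ug/mL in this assay, at which 2 of the 4 values shown sit.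

As far as these compounds go, whether the acetyl changes anything at all once the methyl is present stays open, as neither methylated compound has a number. From the compounds shown here alone, it also stays open whether a different group on that ring nitrogen, such as ethyl or a longer chain, or a different group on the aromatic amine, such as propionyl, would bring a methylated compound back within the measurable range.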